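Taking the Last Methoxy Off Compound 2

A few compounds are considered here, and "the series" means these few. Any claim that something is new, unique, unknown or untested is made for them only; others in the source may bear on it.

In a functional assay on MOLT-4 cells (Homo sapiens) for antiproliferative activity, read by cell counting, with a stated time of 2 days (on this read-out lower numbers stand for stronger inhibition and higher numbers for weaker inhibition), compound 1 `COc1cc(C(=O)c2sc(N3CCCC3)nc2N)cc(OC)c1OC` gives 260 nM. Compound 2 `COc1cccc(C(=O)c2sc(N3CCCC3)nc2N)c1` gives > 200000 nM, which is a limit of this assay and not a number. Compound 3 `Nc1nc(N2CCCC2)sc1C(=O)c1ccccc1` has hydrogen in place of methoxy on an aromatic carbon. Among the measured compounds shown here, no measured pair shows this change on its own. With compound 2 reading > 200000 nM as a limit, nothing in the data points to a gain from losing this methoxy. The expected size of the step is a number no higher from compound 2 to compound 3 (the limit leaves the size open), with no shift beyond the scatter in either direction. The estimate for compound 3 is 200000 nM, with an expected range from 50000 nM to 400000 nM.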

Compound 3, half-maximal inhibitory concentration: > 200000 nM
Compound 3: only a limit was reported; the forecaster's own chance of this, stated with the estimate: 80%; the middle value sits exactly at the limit.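

No step can be read between compound 2 and compound 3, because both readings are limits and not numbers: the limit of > 200000 nM in this assay, at which 2 of the 3 values shown sit.

The compounds shown leave open whether replacing this methoxy with hydrogen changes the antiproliferative activity at all.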